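The source may report more compounds than this note shows. Statements on the series, on what has been measured and on what is new or still open speak of the compounds shown alone.

Compound 1, whose structure is `COc1ccc(CN(C(=O)C(C)Br)c2cc(OC)c(OC)c(OC)c2)cc1O`, is the stronger of the two compounds measured here. In a functional assay on HCT-116 cells (Homo sapiens) for inhibition, read by MTT assay, with a stated time of 48 h (a lower number here means a stronger inhibitor, a higher number a weaker inhibitor), compound 1 gives 140 nM. Compound 2, with the structure `COc1ccc(CNc2cc(OC)c(OC)c(OC)c2)cc1N`, gives in this assay 8270 nM, a much higher number than that of compound 1, and the gap between the two lies well beyond the scatter of repeated measurements. Among the measured compounds shown here, compound 2 differs from compound 1 in more than one place, so those two values show only that the pair stand far apart.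

Compound 3, with the structure `COc1ccc(CN(C(=O)CBr)c2cc(OC)c(OC)c(OC)c2)cc1O`, has not yet been measured in this assay. It differs from compound 1 in a single place: hydrogen in place of methyl on a saturated chain carbon bound to a bromine atom and a carbonyl carbon. For the measured compounds named here, no step between measured compounds isolates this change, so there is nothing to lean on beyond the value of compound 1. The step from compound 1 to compound 3 is expected to be small, a 1.1-fold higher number from compound 1 to compound 3 (0.03 log units; within the scatter), not beyond the scatter in either direction. Compound 3 is therefore estimated to give about 150 nM in this assay, within a range from 50 nM to 500 nM.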

Compound 3, half-maximal inhibitory concentration: 68 nM
Beside the measured number, compound 3's estimate is 2.2-fold (0.34 log units) above it; the range from low to high includes it.
By their numbers in this assay, from the lowest: compound 3; then compound 1; then compound 2.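

Among the compounds shown here, this is the first direct reading at the saturated chain carbon bound to a bromine atom and a carbonyl carbon. In this assay putting hydrogen in place of methyl there gives a 2.1-fold lower number from compound 1 to compound 3 (0.31 log units; beyond the scatter) and so the step from (1-bromoethyl)carbonyl to (bromomethyl)carbonyl is modest, but it lies beyond the scatter and shows that the methyl is not needed for the low number seen with compound 1. Nothing measured here accounts for why the number moves with this change.

As far as these compounds go, what a longer chain such as ethyl would do at this carbon remains open, as does the effect of a chlorine atom or an amine in place of the bromine atom. Compound 2 differs from the other two in more than one place, so it cannot settle the role of the bromine atom.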